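The source may hold more compounds than are shown below. What is called first, only, known or untested is meant among the compounds shown, and "the series" means these compounds.

Of the compounds shown here, two of a shared core have been measured in a functional assay on MCF7 cells (Homo sapiens) for cytotoxicity, read by sulforhodamine B assay, with a stated time of 48 h; on this read-out lower numbers stand for stronger inhibition of growth and higher numbers for weaker inhibition of growth. Compound 1 `COc1ccc(-c2cs/c(=N\NC(=O)c3ccc(O)cc3)n2-c2ccc(OC)cc2OC)cc1` gives 28800 nM and stands at the lowest of the two numbers. Compound 2 `Cc1ccc(-c2cs/c(=N\NC(=O)c3ccc(O)cc3)n2-c2c(C)cccc2C)cc1` gives 95500 nM in this assay, and the gap between compound 1 and compound 2 lies beyond the usual scatter, so compound 1 shows the stronger growth inhibition of the pair.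

Compound 3 `COc1ccc(-n2c(-c3ccc(Cl)cc3)cs/c2=N\NC(=O)c2ccc(O)cc2)c(OC)c1` has not yet been measured. It differs from compound 1 in one place: chloro in place of methoxy on an aromatic carbon, or, read one bond further out, 4-methoxyphenyl to 4-chlorophenyl. Among the measured compounds shown here, no measured pair shows this exchange, so its effect is unknown here. The expectation is a small step, downward or none beyond the scatter, from compound 1 to compound 3 of a 1.4-fold lower number from compound 1 to compound 3 (0.16 log units; within the scatter). Compound 3 is therefore estimated at 20000 nM, within a range from 7000 nM to 60000 nM in this assay.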

Compound 3, concentration for total growth inhibition: < 100000 nM
Compound 3 was reported as a limit; the forecaster's own chance of this, stated with the estimate: 5%; the middle value lies beyond the limit too.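

In this assay, among the compounds shown here, compound 3 gives < 100000 nM, which is a limit and not a number, so no step from compound 1 to compound 3 can be read. The compounds shown leave open whether chloro in place of methoxy strengthens growth inhibition, weakens it, or leaves it unchanged.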